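The source may report more compounds than this note shows. Statements on the series, on what has been measured and on what is new or still open speak of the compounds shown alone.

Compound 1, `CNC(=O)c1cc(Oc2ccc3oc(Nc4ccccc4Cl)nc3c2)ccn1`: in an ADME assay on Caco-2 cells (Homo sapiens) for permeability, in the apical to basolateral direction (on this read-out lower numbers stand for lower permeability and higher numbers for higher permeability), compound 1 gives 10 10^-6 cm/s.
Compound 2, `CNC(=O)c1cc(Oc2ccc3oc(Nc4cccc(C(F)(F)F)c4)nc3c2)ccn1`: compound 2 gives 10 10^-6 cm/s.
Compound 3, `CCc1ccc(Nc2nc3cc(Oc4ccnc(C(=O)NC)c4)ccc3o2)cc1`: compound 3 gives 10 10^-6 cm/s.

Compound 3 stands level with compounds 1 and 2 on these numbers. The three measured compounds share one core and differ only in the phenyl group carried on the nitrogen. Swapping that group gave no change at the digits printed from compound 1 to compound 2 (within the scatter), no change at the digits printed from compound 1 to compound 3 (within the scatter) and no change at the digits printed from compound 2 to compound 3 (within the scatter), so none of these exchanges moved the read-out beyond the scatter.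

Compound 4, `CNC(=O)c1cc(Oc2ccc3oc(Nc4ccc(OC(F)(F)F)cc4)nc3c2)ccn1`, has not yet been measured in this assay. It differs from compound 3 in one place: trifluoromethoxy in place of ethyl on an aromatic carbon, on an aromatic carbon of a six-membered aromatic ring of carbon only, para to a large group. All three measured steps concern the same phenyl group on the nitrogen, and each left the number unchanged within the scatter. The change from compound 3 to compound 4 is a smaller edit of that same group, so no step beyond the scatter is expected. Compound 4 is therefore expected to give about 10 10^-6 cm/s, with a likely range from 5 10^-6 cm/s to 20 10^-6 cm/s, which would mean an expected step of no change at the digits printed from compound 3 to compound 4 (within the scatter).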

Compound 4, apparent permeability: 10 10^-6 cm/s
Compound 4: middle estimate and measured number agree at the digits printed; the range from low to high includes it.
By their numbers in this assay, from the lowest: compounds 1, 2, 3 and 4 (each within the scatter of the next).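

Putting trifluoromethoxy in place of ethyl on an aromatic carbon, para to a large group, gave in this assay no change at the digits printed from compound 3 to compound 4 (within the scatter). The earlier steps shown here each exchanged one whole substituted phenyl group for another, whereas this step holds the place on the ring fixed and changes only the group sitting there, and the two groups differ clearly in make-up: ethyl has 2 heavy atoms, all carbon, and no hydrogen-bond acceptor, while trifluoromethoxy has 5 heavy atoms, including oxygen and fluorine, and 1 hydrogen-bond acceptor. So, for this one pair, that difference in atoms came with no step beyond the scatter, and nothing measured here explains this result.

The compounds shown leave open whether this flat picture would hold with a carboxylic acid, a dimethylamino group or a longer alkyl chain in this same place on the ring. They also leave open how the read-out would respond to a change elsewhere, such as replacing the methyl on the amide with a larger alkyl group, since all four compounds keep the shared core unchanged.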